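This account rests on a few compounds, and the source may have more. Where it says the series, first, only, none or still open, it means among the compounds named here.

The measured compounds are compound 1, `CC(=O)N(C)C(C)C#CCn1cncc1C`, compound 2, `CC(=O)N(C)CC#CCn1cncc1C`, and compound 3, `COC(=O)N(C)CC#CCN1CCCC1`. In a functional assay on the whole organism for agonist activity, with Mus musculus as the target (on this read-out higher numbers stand for an effect only at larger amounts of compound and lower numbers for an effect already at smaller amounts), compound 1 gives > 100 mg/kg, which is a limit of the assay and not a number. In this assay compound 2 likewise gives > 100 mg/kg, again a limit. Among the compounds with values here, compound 3 gives 3 mg/kg in this assay, the only number among the three.

Compound 1 differs from compound 2 by methyl in place of hydrogen on a saturated chain carbon bound to an amide-type nitrogen and a triple-bonded carbon. The step that this change made is a step that the two limits leave unreadable from compound 2 to compound 1, since both values sit at the limit of > 100 mg/kg in this assay, at which 2 of the 3 values shown sit. The difference between the core of compound 3 and the core of compound 2 is not broken down here.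

The unmeasured compound 4, `CCOC(=O)N(C)CC#CCN1CCCC1`, differs from compound 3 by methyl in place of hydrogen on a saturated chain carbon bound to an oxygen next to a carbonyl group. Within the data shown here, this is the same kind of change as the one from compound 2 to compound 1, but the place differs: there the carbon is bound to an amide-type nitrogen and a triple-bonded carbon, here to an oxygen next to a carbonyl group. Because the earlier step reads as a step that the two limits leave unreadable from compound 2 to compound 1, it gives no guidance on size, so compound 4 is expected to stay close to compound 3, with a step of a 1.3-fold higher number from compound 3 to compound 4 (0.12 log units; within the scatter) in this assay. Compound 4 is estimated at 4 mg/kg, between 1.5 mg/kg and 12 mg/kg.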

Compound 4, dose for half-maximal effect: > 100 mg/kg
Compound 4: no number, only a limit (the forecaster's own chance of this, stated with the estimate: 10%); at least 25-fold (1.39 log units) between middle value and limit.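

In this assay, methyl in place of hydrogen on the core of compound 3, which turns methoxycarbonyl into ethoxycarbonyl, gives an at least 33-fold higher number from compound 3 to compound 4 (1.52 log units; beyond the scatter), so on this core the change is large. Within the data shown here, this does not show that the change carries from one core to another: the only other step of this kind, from compound 2 to compound 1, cannot be read and lies at a different place, so the series offers neither agreement nor disagreement between the two cores. Compound 4 stands at a limit and not at a number, so the new step has a lower bound only, and the same limit recurs across the series: the limit of > 100 mg/kg in this assay, at which 3 of the 4 values shown sit.

As far as these compounds go, it remains open whether any group on this core other than methoxycarbonyl keeps an effect, for instance propoxycarbonyl or an amine in place of the methoxy. From the compounds shown here alone, it also remains open whether the same methyl would matter at the corresponding place on a core that gives a number in this assay.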